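The compounds below may be only part of what the source reports. "The series", "measured", "known", "first", "only" and "open" are said of these compounds alone.

Of the compounds shown here, three sharing one core have been measured so far, and they differ only in the group on an amide-type nitrogen. In a functional assay on L1210 cells (Mus musculus) for inhibition (on this read-out higher numbers stand for weaker inhibition and lower numbers for stronger inhibition), compound 2 `C/C(=C\COC(=O)Nc1ccccc1)C1=CC(=O)C(C)(C)O1`, which carries phenyl there, gives > 200 ug/mL. This is a limit of the assay and not a number, and the limit of > 200 ug/mL in this assay, at which 1 of the 3 values shown sits, is the only such case among the measured compounds. Even so, compound 2 is the weakest of the three. With butyl in the same place, compound 1 `CCCCNC(=O)OC/C=C(\C)C1=CC(=O)C(C)(C)O1` gives 2.6 ug/mL. With tert-butyl, compound 3 `C/C(=C\COC(=O)NC(C)(C)C)C1=CC(=O)C(C)(C)O1` gives 4.1 ug/mL.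

The next structure is compound 4 `C/C(=C\COC(=O)NC(C)C)C1=CC(=O)C(C)(C)O1`, where isopropyl replaces phenyl, turning anilino into isopropylamino: isopropyl in place of phenyl on an amide-type nitrogen.

Within the data shown here, three measured steps bear on this change. Phenyl in place of butyl gave an at least 76-fold higher number from compound 1 to compound 2 (1.88 log units; beyond the scatter), and tert-butyl in place of phenyl gave an at least 48-fold lower number from compound 2 to compound 3 (1.68 log units; beyond the scatter). Tert-butyl in place of butyl gave only a 1.6-fold higher number from compound 1 to compound 3 (0.20 log units; within the scatter). Isopropyl, like butyl and tert-butyl, has no ring, so compound 4 is expected to land close to compound 1 and compound 3. The expected change is large and towards stronger inhibition, with an estimated at least 57-fold lower number from compound 2 to compound 4 (1.75 log units; beyond the scatter). For compound 4 the expected value is 3.5 ug/mL, with an estimated range from 1.3 ug/mL to 10 ug/mL.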

Compound 4, half-maximal inhibitory concentration: 4.9 ug/mL
For compound 4 the middle estimate is 1.4-fold (0.15 log units) below the measured one; measured number inside the range.
By their numbers in this assay, from the lowest: compounds 1, 3 and 4 (each within the scatter of the next). At a limit, above all of these: compound 2.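

Isopropyl is a third group without a ring on this amide-type nitrogen, and it again sits far from phenyl, with an at least 40-fold lower number from compound 2 to compound 4 (1.61 log units; beyond the scatter). That size is a lower bound, since the figure for compound 2 is a limit of the assay and not a number: the limit of > 200 ug/mL in this assay, at which 1 of the 4 values shown sits. Among the groups without a ring, trading tert-butyl for isopropyl gives a 1.2-fold higher number from compound 3 to compound 4 (0.08 log units; within the scatter), and trading butyl for isopropyl gives a 1.9-fold higher number from compound 1 to compound 4 (0.28 log units; within the scatter), so straight and branched chains of these sizes cannot be told apart here, and among the four compounds only phenyl, the one group with a ring, goes against this flat picture.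

From the compounds shown here alone, what remains open is whether the sharp loss of inhibition goes with any ring on this nitrogen or only with an aromatic ring placed directly on it, a question that cyclohexyl or benzyl in the same place would help to settle. Also open, going by these compounds, is how far the flat picture extends, for instance to a longer chain such as octyl or to a chain that ends in an amine or a carboxylic acid.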